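This account rests on a few compounds, and the source may have more. Where it says the series, first, only, none or still open, it means among the compounds named here.

Measured compounds:
- compound 1 `c1coc(-c2ccnc(-c3cccs3)c2)c1`, in a functional assay on A549 cells (Homo sapiens) for antiproliferative activity (on this read-out higher numbers stand for an effect only at larger amounts of compound and lower numbers for an effect already at smaller amounts), compound 1 gives 118000 nM
- compound 2 `C(=C/c1cccs1)\c1cc(-c2cccs2)cc(-c2cccs2)n1`, compound 2 gives 118000 nM
- compound 3 `c1coc(-c2ccnc(-c3ccco3)c2)c1`, compound 3 gives 118000 nM

On these numbers compound 1 sits level with compounds 2 and 3; none of the three is separated from the others beyond the scatter. Compound 4 `c1coc(-c2cc(-c3cccs3)nc(-c3cccs3)c2)c1` differs from compound 1 in one place: thiophen-2-yl in place of hydrogen on an aromatic carbon. For the measured compounds named here, the one directly comparable step, no change at the digits printed from compound 1 to compound 3 (within the scatter), swapped one small aromatic ring for another without moving the read-out. Compound 2, which also carries three such rings on the shared core, shows the same value as compound 1. Going by the values given here, no measured step therefore points to a shift in either direction, and for compound 4 the step of no change at the digits printed from compound 1 to compound 4 (within the scatter) is expected to stay within the scatter. Compound 4 is expected to give about 118000 nM, within 60000 nM to 236000 nM.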

Compound 4, half-maximal effective concentration: 118000 nM
Estimate against measurement, compound 4: no gap at the digits printed; the range from low to high includes it.
By their numbers in this assay, from the lowest: compounds 1, 2, 3 and 4 (each within the scatter of the next).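

In this assay, thiophen-2-yl in place of hydrogen next to the ring nitrogen gives no change at the digits printed from compound 1 to compound 4 (within the scatter), so the read-out holds here. The earlier step only exchanged one ring for another, whereas this one puts a whole new ring on a carbon that carried only hydrogen. No measurement shown gives a reason for this unchanged value. Still open, going by these compounds, is whether an amine, a carboxylic acid or a longer chain at this position would give a value different from that of compound 1.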